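A few compounds are considered here, and "the series" means these few. Any claim that something is new, unique, unknown or untested is made for them only; others in the source may bear on it.

Measured compounds in an ADME assay on K562 cells (Homo sapiens) for antiproliferative activity; on this read-out lower numbers stand for stronger inhibition and higher numbers for weaker inhibition:
compound 1 `COc1ccc2nccc(CC[C@H]3OC[C@H](NCc4ccc5c(n4)NC(=O)CO5)CO3)c2c1`: 24000 nM
compound 2 `COc1ccc2nccc(CC[C@H]3OC[C@H](NCc4ccc5c(n4)NC(=O)CS5)CO3)c2c1`: 31000 nM
compound 3 `COc1ccc2nccc(CC[C@H]3CC[C@H](NCc4ccc5c(c4)OCCO5)CC3)c2c1`: 4200 nM

Compound 1 stands second highest of the three numbers. Its nearest neighbour is compound 2, with a 1.3-fold higher number from compound 1 to compound 2 (0.11 log units; within the scatter), so the two are not separated by this assay. Within the data shown here, compound 3 differs from compound 1 in two places, the core and the group on the amine, and no single step can be drawn; compound 3 gives 4200 nM, well below the number of compound 1.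

Compound 4 `COc1ccc2nccc(CC[C@H]3OC[C@H](NCc4ccc(Cl)cc4)CO3)c2c1` is the next step from compound 1: a group of 7 heavy atoms (6 carbon, 1 chlorine; one six-membered aromatic ring of carbon only) in place of a group of 11 heavy atoms (7 carbon, 2 nitrogen, 2 oxygen; one six-membered non-aromatic ring with 2 hetero atoms, one six-membered aromatic ring with 1 hetero atom), on a saturated chain carbon bound to an amine nitrogen. Among the measured compounds shown here, the only measured step at the same place, from compound 1 to compound 2, exchanged one bicyclic group for a close relative and stayed within the scatter. For the measured compounds named here, the present change removes the bicyclic group altogether for 4-chlorophenyl, and no measured step covers such a swap. Compound 3 shows that a plainer aromatic group can sit on this amine in a compound with a low number, but its core differs as well, so it gives no clean reading. In this assay compound 4 is therefore expected to give roughly 15000 nM, within 4000 nM to 50000 nM. The expected step, a 1.6-fold lower number from compound 1 to compound 4 (0.20 log units; within the scatter), is estimated to stay within the scatter, with wide uncertainty.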

Compound 4, half-maximal inhibitory concentration: 12000 nM
Compound 4: middle estimate off by 1.3-fold (0.10 log units), on the high side; the measured number falls inside the stated range.
By their numbers in this assay, from the lowest: compound 3; then compounds 4, 1 and 2 (each within the scatter of the next, the first and the last beyond it).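

In this assay, 4-chlorophenyl can take the place of the bicyclic group on the saturated chain carbon bound to an amine nitrogen, giving a 2.0-fold lower number from compound 1 to compound 4 (0.30 log units; within the scatter), so this assay does not separate the two groups even though the hydrogen-bond donor and acceptors of the group that leaves are absent. Starting from the sulfur-containing bicyclic group, the same exchange gives a 2.6-fold lower number from compound 2 to compound 4 (0.41 log units; beyond the scatter), a modest step and the only one at this place that lies beyond the scatter. No measurement at hand accounts for either step. On these data alone, it remains open whether the chlorine contributes anything, which a plain phenyl group or a 4-methoxyphenyl group on the same amine would test. Also open, as far as these compounds go, is how much of the lower number of compound 3 belongs to its group on the amine, and how much to its core, since that group has not been seen on the core of compound 1 here.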